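The source may hold more compounds than are shown below. What is called first, only, known or untested is meant among the compounds shown, and "the series" means these compounds.

Compound 1 `O=C(/C=C/c1ccc([N+](=O)[O-])o1)c1ccc(I)cc1` was examined in an ADME assay on Vero cells (Chlorocebus sabaeus) for cytotoxicity, read by resazurin assay, with a stated time of 72 h; a higher number here means that more compound is tolerated, a lower number that less compound is tolerated. In this assay compound 1 gives only a limit, > 100000 nM. Compound 2 `COc1ccc(/C=C/C(=O)c2cccc(I)c2)cc1` also gives only a limit in this assay, > 100000 nM. Compound 1 thus stands at the limit of > 100000 nM in this assay, at which 2 of the 2 values shown sit, with no number beneath it. Compound 3 `O=C(/C=C/c1ccc([N+](=O)[O-])o1)c1ccc(C2CCCCC2)cc1` differs from compound 1 by cyclohexyl in place of iodo on an aromatic carbon. For the measured compounds named here, no measured step in this assay is available for comparison, so the expected step of an at least 1.2-fold lower number from compound 1 to compound 3 (0.09 log units; that floor lies within the scatter) is taken as small, at most a modest move toward less tolerance, or none beyond the scatter. Compound 3 is expected to give 80000 nM, with a range from 30000 nM to 200000 nM.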

Compound 3, half-maximal cytotoxic concentration: > 100000 nM
Compound 3 was reported as a limit; the forecaster's own chance of this, stated with the estimate: 50%; middle value at least 1.2-fold (0.09 log units) from the limit.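

In this assay, for the compounds shown here, compound 1 and compound 3 both give only limits, so no step between them can be read: the limit of > 100000 nM in this assay, at which 3 of the 3 values shown sit. The compounds shown leave open whether cyclohexyl in place of iodo changes tolerance at all.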